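A Second Chloro on the Pendant Phenyl

A few compounds are considered here, and "the series" means these few. Any claim that something is new, unique, unknown or untested is made for them only; others in the source may bear on it.

Compound 1 `CC(=O)c1cc2ccc(OCCCn3cc(CNC(=O)CCCCC4CCSS4)nn3)cc2oc1=O` gives 37.5% in a functional assay on PC-12 cells (Rattus norvegicus) for cytotoxicity, read by MTT assay, with stated times of 3 h and 2 h, tested at 5 uM; a lower number here means a weaker effect, a higher number a stronger effect of the compound at the concentration tested.
Compound 2 `O=C(CCCCC1CCSS1)NCc1cn(CCCOc2ccc3cc(-c4ccccc4)c(=O)oc3c2)nn1` gives 29.8% in this assay.
Compound 3 `O=C(CCCCC1CCSS1)NCc1cn(CCCOc2ccc3cc(-c4ccc(Cl)cc4)c(=O)oc3c2)nn1` gives 60.6% in this assay.

Of the three measured compounds, compound 3 stands highest in this assay: the step of a number 23.1 percentage points higher from compound 1 to compound 3 (beyond the scatter) and the step of a number 30.8 percentage points higher from compound 2 to compound 3 (beyond the scatter) both lie beyond the scatter. Compound 4 `O=C(CCCCC1CCSS1)NCc1cn(CCCOc2ccc3cc(-c4ccc(Cl)c(Cl)c4)c(=O)oc3c2)nn1` differs from compound 3 in one place: chloro in place of hydrogen on an aromatic carbon. The earlier step that bears on this change is the one in which a chloro first entered this ring, a number 30.8 percentage points higher from compound 2 to compound 3 (beyond the scatter), a large step upward. The step of a number 7.7 percentage points lower from compound 1 to compound 2 (within the scatter) lies within the scatter and offers no guidance. With one earlier step of this kind pointing upward and none pointing down, a further increase in this assay is expected for compound 4, though a smaller one; a single earlier step is a thin basis. The expected step is a number 7.4 percentage points higher from compound 3 to compound 4 (within the scatter). Compound 4 is therefore estimated at 68%, with a range from 50% to 85%.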

Compound 4, a percentage reported as activity, at one concentration (the size of the read-out at that concentration, not a potency): 44.7%
Estimate against measurement, compound 4: 23.3 percentage points above; measured number outside the range, below it.
By their numbers in this assay, from the lowest: compounds 2, 1 and 4 (each within the scatter of the next, the first and the last beyond it); then compound 3.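

The second chloro runs against the first in this assay, and the two steps on this ring point in opposite directions (a number 15.9 percentage points lower from compound 3 to compound 4 (beyond the scatter)) for the second chloro against (a number 30.8 percentage points higher from compound 2 to compound 3 (beyond the scatter)) for the first. Part of the rise over plain phenyl remains (a number 14.9 percentage points higher from compound 2 to compound 4 (beyond the scatter)), while 3,4-dichlorophenyl and the acetyl of compound 1 can no longer be told apart (a number 7.2 percentage points higher from compound 1 to compound 4 (within the scatter)). Among these compounds, then, more chloro on the ring does not go with a higher number, and nothing measured here accounts for this reversal.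

The compounds shown leave open whether the fall belongs to chloro itself or to any added group in this place. A methoxy, a fluoro or an amine there could settle that question.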